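Allylamino to Butylamino on a Shared Enaminone Core

The compounds below may be only part of what the source reports. "The series", "measured", "known", "first", "only" and "open" are said of these compounds alone.

Compound 1 `C=CCNC(=C\C(=O)/C=C/c1ccc(O)c(OC)c1)/C=C/c1ccc(O)c(OC)c1` — 89%
Compound 2 `CC(=O)Oc1ccc(/C=C/C(=O)/C=C(/C=C/c2ccc(OC(C)=O)cc2)NCC(C)C)cc1` — 102%
Compound 3 `O=C(/C=C(/C=C/c1ccc(O)cc1)NC1CCCCC1)/C=C/c1ccc(O)cc1` — 97%

Of the compounds shown here, three have been measured in a functional assay on Caco-2 cells (Homo sapiens), read by fluorescence, tested at 1 uM; a lower number here means a stronger effect, a higher number a weaker effect of the compound at the concentration tested. Compound 1 gives the lowest number of the three, 89%, in this assay. The nearest of the other two is compound 3, whose value of 97% lies within the usual scatter of compound 1, so the two cannot be told apart. Compound 2 stands furthest away with 102%, and this gap from compound 1 lies beyond the scatter.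

The unmeasured compound 4 `CCCCNC(=C\C(=O)/C=C/c1ccc(O)c(OC)c1)/C=C/c1ccc(O)c(OC)c1` differs from compound 1 in one place only: propyl in place of vinyl on a saturated chain carbon bound to an amine nitrogen. Read one bond further out, the change is allyl to butyl, or allylamino to butylamino. The two aryl ends and the central chain are unchanged.

Within the data shown here, no pair of measured compounds differs in a single place, so no measured step is available to guide the estimate for this change. A chain of three carbons in place of one of two carbons with a double bond is a modest alteration, and compound 4 is expected to stay close to compound 1, with a step of a number 1 percentage points higher from compound 1 to compound 4 (within the scatter) in this assay, not beyond the scatter. Compound 4 is thus estimated at 90%, within a range from 78% to 102%.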

Compound 4, a percentage reported as activity, at one concentration (the size of the read-out at that concentration, not a potency): 91%
The estimate for compound 4 lay 1 percentage points below the measured number; low and high end bracket the measured number.
By their numbers in this assay, from the lowest: compounds 1, 4, 3 and 2 (each within the scatter of the next, the first and the last beyond it).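

Among these compounds, this pair gives the first comparison in the set that differs in one place only. In this assay, propyl in place of vinyl on a saturated chain carbon bound to an amine nitrogen gives a number 2 percentage points higher from compound 1 to compound 4 (within the scatter), so the two compounds cannot be told apart, and on this core, at the single concentration tested, the read-out tolerates both the loss of the double bond outside aromatic rings and the added carbon, with allylamino and butylamino behaving alike. No evidence accompanies the pair to explain this result.

The compounds shown leave open how far this tolerance extends, since compounds 2 and 3 differ from compound 1 in more than one place and their isobutyl and cyclohexyl groups therefore cannot be read as steps at this position. Whether a longer chain such as octyl, a chain ending in a carboxylic acid or in a second amine, or a benzyl group on the same nitrogen of the core of compound 1 would give a step beyond the scatter remains an open question.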